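Cyano in place of hydrogen on selenium

A few compounds are considered here, and "the series" means these few. Any claim that something is new, unique, unknown or untested is made for them only; others in the source may bear on it.

Compound 1 `[SeH]c1nc2ccccc2s1` carries a selenol on its aromatic core; in a functional assay on PC-3 cells (Homo sapiens) for cytotoxicity, read by MTT assay, with a stated time of 72 h (on this read-out higher numbers stand for weaker inhibition of growth and lower numbers for stronger inhibition of growth), compound 1 gives > 50000 nM, which is a limit of the assay rather than a number. Compound 2 `N#CSc1nc2ccccc2s1` gives 66300 nM, and the step that the limit leaves unreadable from compound 1 to compound 2 therefore cannot be sized. Compound 3 `O=C1c2ccccc2C(=O)N1C[SeH]` gives 9400 nM, the lower of the two numbers measured, with compound 2 standing higher. Compound 4 `N#C[Se]CN1C(=O)c2ccccc2C1=O` differs from compound 3 by cyano in place of hydrogen on a selenium. Within the data shown here, the only measured step, from compound 1 to compound 2, also introduces a nitrile, but its size is hidden by the limit of compound 1 (the limit of > 50000 nM in this assay, at which 1 of the 3 values shown sits), so no direction beyond the scatter can be drawn from it. Compound 4 is estimated at 9000 nM, between 3000 nM and 30000 nM, an expected step of a 1.0-fold lower number from compound 3 to compound 4 (0.02 log units; within the scatter).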

Compound 4, concentration for total growth inhibition: 32100 nM
Compound 4: the middle estimate sits 3.6-fold (0.55 log units) below what was measured; the measured number lies above the stated range.
By their numbers in this assay, from the lowest: compound 3; then compound 4; then compound 2.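

On a selenium attached to a saturated chain carbon, cyano in place of hydrogen gives a 3.4-fold higher number from compound 3 to compound 4 (0.53 log units; beyond the scatter), so growth inhibition in this assay weakens with this change. Among these compounds, this is the first change involving a nitrile whose size can be read. The earlier step cannot be sized because compound 1 stands at a limit: the limit of > 50000 nM in this assay, at which 1 of the 4 values shown sits.

From the compounds shown here alone, whether the same direction holds on the aromatic core of compound 1 stays open. So does the outcome of putting a methyl or an acetyl group on this selenium.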